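Cyclic hexapeptide series: lysine-like side chain swapped

A few compounds are considered here, and "the series" means these few. Any claim that something is new, unique, unknown or untested is made for them only; others in the source may bear on it.

Measured so far in an assay on COS-7 cells for inhibition of disintegrin and metalloproteinase domain-containing protein 8 (Homo sapiens), read by ELISA, with a stated time of 6 h; a lower number here means a stronger inhibitor, a higher number a weaker inhibitor:
- compound 1, `CC(C)C[C@@H]1NC(=O)[C@H](CCCNC(=N)N)NC(=O)[C@H](CCCCN)NC(=O)[C@H](CC(=O)O)NC(=O)[C@H](CCCCN)NC(=O)[C@H](CO)NC1=O`, compound 1 gives 240 nM
- compound 2, `CCC[C@@H]1NC(=O)[C@H](CCCNC(=N)N)NC(=O)[C@H](CCCCN)NC(=O)[C@H](CC(=O)O)NC(=O)[C@H](CCCCN)NC(=O)CCNC1=O`, compound 2 gives 452 nM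
- compound 3, `CC(C)C[C@@H]1NC(=O)[C@H](CCCNC(=N)N)NC(=O)[C@H](CN)NC(=O)[C@H](CC(=O)O)NC(=O)[C@H](CCCCN)NC(=O)CCNC1=O`, compound 3 gives only a limit, > 5000 nM

Compounds 1 and 2 sit within the usual scatter of each other, so the numbers set no order between them. Compound 3 stands apart: its value is a limit of the assay and not a number, and it is the one of the three that sits at the limit described by the limit of > 5000 nM in this assay, at which 1 of the 3 values shown sits. Within the data shown here, no two measured compounds differ in exactly one place, so no single step between measured compounds is available.

Compound 4, `CC(C)C[C@@H]1NC(=O)[C@H](CCCNC(=N)N)NC(=O)[C@H](CCCC[N+](C)(C)C)NC(=O)[C@H](CC(=O)O)NC(=O)[C@H](CCCCN)NC(=O)CCNC1=O`, follows from compound 3 by a group of 7 heavy atoms (6 carbon, 1 nitrogen; no ring) in place of one nitrogen atom, on a saturated chain carbon bound to a saturated ring carbon. This puts a group of 7 heavy atoms (6 carbon, 1 nitrogen; no ring), counted with a net charge of +1 and no hydrogen-bond donors or acceptors, in place of the amino group that compound 3 carries on a saturated chain carbon bound to a saturated ring carbon.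

Among the measured compounds shown here, with no measured step to lean on, the expectation for the change from compound 3 to compound 4 in this assay is a move back toward a measurable number, estimated as an at least 2.5-fold lower number from compound 3 to compound 4 (0.39 log units; beyond the scatter). Compound 4 is expected to give about 2000 nM, within a range from 500 nM to 8000 nM.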

Compound 4, half-maximal inhibitory concentration: > 10000 nM
Compound 4: only a limit was reported; the forecaster's own chance of this, stated with the estimate: 35%; middle value at least 5.0-fold (0.69 log units) from the limit.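

In this assay compound 4 gives > 10000 nM, a limit of the assay and not a number. Compound 3 gives > 5000 nM, also a limit. Among these compounds, with limits on both sides, no step from compound 3 to compound 4 can be read. The compounds shown leave open how these two compounds rank against each other in this assay.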